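Replacing the Dichlorophenylamino Arm of Compound 2

The source may report more compounds than this note shows. Statements on the series, on what has been measured and on what is new or still open speak of the compounds shown alone.

Measured compounds in a functional assay on PC-3 cells (Homo sapiens) for inhibition, read by sulforhodamine B assay, with a stated time of 48 h, tested at 100 uM; on this read-out higher numbers stand for a weaker effect at the one concentration tested and lower numbers for a stronger effect:
- compound 1, `O=C(Nc1cccc(-n2cc(-c3ccncc3)c(-c3cc(O)cc(Cl)c3)n2)c1)Nc1ccc(Cl)c(Cl)c1`, gives -35%
- compound 2, `COc1cc(Cl)cc(-c2nn(-c3cccc(NC(=O)Nc4ccc(Cl)c(Cl)c4)c3)cc2-c2ccncc2)c1`, gives -24%

Among the measured compounds shown here, compound 2 stands at the higher of the two numbers, and its only neighbour is compound 1, with the change being a number 11 percentage points higher from compound 1 to compound 2 (beyond the scatter).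

Compound 3, `COc1cc(Cl)cc(-c2nn(-c3cccc(NC(=O)c4cccc(C(F)(F)F)c4)c3)cc2-c2ccncc2)c1`, is not yet measured in this assay. It differs from compound 2 in the following way: 3-(trifluoromethyl)phenyl in place of (3,4-dichlorophenyl)amino on a carbonyl carbon. For the measured compounds named here, the one measured step, the methyl in place of hydrogen on an oxygen on an aromatic ring between compound 1 and compound 2, touches a different part of the molecule and does not bear on the exchange at the carbonyl carbon; no measured pair shows what removing the (3,4-dichlorophenyl)amino group and bringing in 3-(trifluoromethyl)phenyl does here. The read-out for compound 2 in this assay is itself modest, so the room for a weaker number is limited. On that basis compound 3 is expected to give -15% in this assay, within -45% to 15%, which means an expected step of a number 9 percentage points higher from compound 2 to compound 3 (within the scatter) that may well not exceed the scatter.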

Compound 3, a percentage reported as activity, at one concentration (the size of the read-out at that concentration, not a potency): 17%
Compound 3: the middle estimate sits 32 percentage points below what was measured; measured number outside the range, above it.
By their numbers in this assay, from the lowest: compound 1; then compound 2; then compound 3.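

In this assay, among the compounds shown here, the arm on the carbonyl carbon matters far more than the earlier compounds could show: 3-(trifluoromethyl)phenyl in place of (3,4-dichlorophenyl)amino gives a number 41 percentage points higher from compound 2 to compound 3 (beyond the scatter), whereas the only earlier step, on the oxygen at the other aromatic ring, was a modest one of a number 11 percentage points higher from compound 1 to compound 2 (beyond the scatter). The result shows that this arm is not a neutral part of the molecule, since the exchange at this one place leaves a much weaker effect at the one concentration tested, with compound 3 at 17%. No measurement at hand explains the size of this step.

The exchange alters the atom on the carbonyl carbon and the ring substituents together, with a group carrying 1 hydrogen-bond donor giving way to one carrying 0, so the two changes cannot be told apart from these compounds. The arms that would separate them, (3-(trifluoromethyl)phenyl)amino and 3,4-dichlorophenyl directly on the carbonyl carbon, lie outside the compounds shown, and so does the effect of the same exchange with the hydroxy group of compound 1 in place of the methoxy group.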